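The source may report more compounds than this note shows. Statements on the series, on what has been measured and on what is new or still open speak of the compounds shown alone.

Measured so far:
compound 1, `CCOC(=O)c1ccc(NC(=O)N2CC2C#N)cc1`: 7700 nM
compound 2, `N#CC1CN1C(=O)Nc1ccc(Cl)cc1Cl`: 35000 nM

Both were tested in a functional assay on OVCAR-3 cells (Homo sapiens) for inhibition; a lower number here means a stronger inhibitor, a higher number a weaker inhibitor. Compound 1 holds the lower of the two numbers; compound 2 stands well above it, and that gap is beyond the usual scatter. Compound 3, `N#CC1CN1C(=O)Nc1ccccc1`, is not yet measured; it differs from compound 1 by hydrogen in place of ethoxycarbonyl on an aromatic carbon. Among the measured compounds shown here, no pair of measured compounds shows what this change alone does, so the expectation rests on the values themselves. The step of a 1.9-fold higher number from compound 1 to compound 3 (0.29 log units; within the scatter) is expected to be a modest loss, toward a higher number. For compound 3 the expected value in this assay is 15000 nM, within 5000 nM to 50000 nM.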

Compound 3, half-maximal inhibitory concentration: 6800 nM
Compound 3: middle estimate off by 2.2-fold (0.34 log units), on the high side; the range from low to high includes it.
By their numbers in this assay, from the lowest: compounds 3 and 1 (each within the scatter of the next); then compound 2.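

In this assay hydrogen in place of ethoxycarbonyl on the aromatic carbon gives a 1.1-fold lower number from compound 1 to compound 3 (0.05 log units; within the scatter) and so leaves the two compounds indistinguishable. In this pair, all 5 heavy atoms of ethoxycarbonyl can go from this position, para to a group of 8 heavy atoms, with no measurable difference in inhibition. No measurement shown gives a reason for this result. The compounds shown leave open whether an amine, a carboxylic acid or a longer chain at this same position would also leave the number within the scatter.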